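This account rests on a few compounds, and the source may have more. Where it says the series, first, only, none or still open, it means among the compounds named here.

Going by the values given here, compound 1 `Nc1cc(N)c2nc(-c3ccccc3)c(Sc3ccc(F)cc3)nc2c1` holds the only numerical reading: in a functional assay on NCI-H23 cells (Homo sapiens) for inhibition, read by sulforhodamine B assay, with a stated time of 48 h (a lower number here means a stronger inhibitor of growth, a higher number a weaker inhibitor of growth), compound 1 gives 39800 nM. Compound 2 `CCOC(=O)[C@H](CCC(=O)O)NC(=O)c1ccc(CNc2nc3cc(N)cc(N)c3nc2-c2ccccc2)cc1` was also run in this assay, and compound 2 gives < 100000 nM, which is a limit of the assay and not a number. Among the compounds with values here, no two measured compounds differ in a single place, so no measured step is available to calibrate a change on the shared core; the only further reading is the limit of < 100000 nM in this assay, at which 1 of the 2 values shown sits.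

Compound 3 `COc1ccc(Sc2nc3cc(N)cc(N)c3nc2-c2ccccc2)cc1` remains to be measured in this assay. It differs from compound 1 at one point: methoxy in place of fluoro on an aromatic carbon. The change sits on an aromatic carbon of a six-membered aromatic ring of carbon only, para to a large group, and swaps one small substituent for another. With nothing in the measured set to indicate otherwise, the step from compound 1 in this assay is expected to be a 1.0-fold higher number from compound 1 to compound 3 (0.00 log units; within the scatter), that is, no movement beyond the usual scatter in either direction. Compound 3 is therefore estimated at 40000 nM, with a range from 12000 nM to 130000 nM.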

Compound 3, concentration for total growth inhibition: < 100000 nM
Compound 3: no number, only a limit; the forecaster's own chance of this, stated with the estimate: 25%; the middle value does not contradict the limit.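

In this assay compound 3 gives < 100000 nM, which is a limit of the assay and not a number, so no step from compound 1 to compound 3 can be read: the limit of < 100000 nM in this assay, at which 2 of the 3 values shown sit.

Going by these compounds, whether methoxy in place of fluoro on this aromatic carbon shifts growth inhibition in either direction, and by how much, stays open.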